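Swapping a Carbamate for a Sulfonamide on Compound 3

The compounds below may be only part of what the source reports. "The series", "measured", "known", "first", "only" and "open" are said of these compounds alone.

In a functional assay on CHO-K1 cells for agonist activity at Glucose-dependent insulinotropic receptor (Homo sapiens), read by a luciferase reporter, with a stated time of 5 h (a lower number here means that less compound is needed, a higher number that more compound is needed for the effect), compound 1 `CC(C)OC(=O)N1CCC(Oc2cccc3c2CCN3c2ccc(S(C)(=O)=O)cc2)CC1` gives 501 nM. Compound 2 `CC(C)OC(=O)N1CCC(Oc2ncnc3c2CCN3c2ccc(C#N)cc2F)CC1` gives 63.1 nM in this assay. Compound 3 `CS(=O)(=O)c1ccc(N2CCc3c(OC4CCN(C(=O)OCCF)CC4)ncnc32)c(F)c1` gives 501 nM in this assay: it sits level with compound 1 within the scatter, the two together being the highest of the three numbers, while compound 2 lies a step beyond the scatter away. Compound 4 `CC(C)S(=O)(=O)N1CCC(Oc2ncnc3c2CCN3c2ccc(S(C)(=O)=O)cc2F)CC1` differs from compound 3 in one place: isopropylsulfonyl in place of (2-fluoroethoxy)carbonyl on an amine nitrogen in a ring. Among the compounds with values here, no measured pair shows this exchange, so its effect cannot be read from the data. The expected step of a 1.3-fold lower number from compound 3 to compound 4 (0.10 log units; within the scatter) in this assay is none beyond the scatter. Compound 4 is therefore estimated at 400 nM in this assay, with a range from 100 nM to 1600 nM.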

Compound 4, half-maximal effective concentration: 1260 nM
Compound 4: the middle estimate sits 3.2-fold (0.50 log units) below what was measured; the measured number falls inside the stated range.
By their numbers in this assay, from the lowest: compound 2; then compounds 1 and 3 (each within the scatter of the next); then compound 4.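

In this assay, within the data shown here, the exchange of (2-fluoroethoxy)carbonyl for isopropylsulfonyl on an amine nitrogen in a ring gives a 2.5-fold higher number from compound 3 to compound 4 (0.40 log units; beyond the scatter) and so gives the first readable step at this position. The group on this nitrogen can therefore shift the number beyond the scatter, even though both groups hold 6 heavy atoms and 2 hydrogen-bond acceptors. Nothing measured here accounts for the step. The compounds shown leave open whether the sulfonyl link or the isopropyl part carries this step, and how a methylsulfonyl or acetyl group on the same nitrogen would read.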